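The source may hold more compounds than are shown below. What is called first, only, known or untested is meant among the compounds shown, and "the series" means these compounds.

Working notes on the series. Compound 1 `Cc1ccc2c(c1)[n+]([O-])c(C#N)c(NS(=O)(=O)c1ccc3ccccc3c1)[n+]2[O-]` in an ADME assay on cells (Peritoneal macrophage cell, Mus musculus) for cytotoxicity, read by trypan blue exclusion, with a stated time of 48 h (on this read-out higher numbers stand for lower toxicity in this test and lower numbers for higher toxicity in this test), gives > 245000 nM, which is a limit of the assay rather than a number (the limit of > 245000 nM in this assay, at which 1 of the 3 values shown sits). Of the two numbers shown, compound 2 `CC(=O)Oc1ccccc1C(=O)Nc1c(C#N)[n+]([O-])c2cc(C)ccc2[n+]1[O-]` gives 21700 nM in this assay, and compound 3 `CC(=O)Oc1ccccc1C(=O)Nc1c(C#N)[n+]([O-])c2cc(C)c(C)cc2[n+]1[O-]` gives 12500 nM in this assay; the step of a 1.7-fold lower number from compound 2 to compound 3 (0.24 log units; within the scatter) stays within the scatter. Compound 4 `CC(=O)Oc1ccccc1C(=O)Nc1c(C#N)[n+]([O-])c2cc(F)ccc2[n+]1[O-]` is not yet measured and differs from compound 2 by fluoro in place of methyl on an aromatic carbon. Among the compounds with values here, no measured step exchanges methyl for fluoro; the only measured change to a ring substituent on the core, a 1.7-fold lower number from compound 2 to compound 3 (0.24 log units; within the scatter), stayed within the scatter, so in this assay no step beyond the scatter is expected in either direction. Compound 4 is therefore estimated at 24000 nM, between 8000 nM and 75000 nM, which amounts to the expected step of a 1.1-fold higher number from compound 2 to compound 4 (0.04 log units; within the scatter).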

Compound 4, half-maximal cytotoxic concentration: 13600 nM
Compound 4: the middle estimate sits 1.8-fold (0.25 log units) above what was measured; low and high end bracket the measured number.
By their numbers in this assay, from the lowest: compounds 3, 4 and 2 (each within the scatter of the next). At a limit, above all of these: compound 1.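

In this assay, fluoro in place of methyl on the aromatic carbon gives a 1.6-fold lower number from compound 2 to compound 4 (0.20 log units; within the scatter). This is the first exchange shown at this position itself, and with the step inside the scatter, the methyl of compound 2 is not needed there to hold the number in this range. Nothing shown bears on a reason for this step. Still open, as far as these compounds go, is whether an amine, a carboxylic acid or a longer chain at this position would give a step beyond the scatter.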